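Chloro for Bromo: A Step Expected Within the Scatter

This account rests on a few compounds, and the source may have more. Where it says the series, first, only, none or still open, it means among the compounds named here.

Going by the values given here, in a functional assay on MKN-45 cells (Homo sapiens) for antiproliferative activity, read by MTT assay, with a stated time of 72 h (a lower number here means a stronger inhibitor, a higher number a weaker inhibitor), compound 1 `COc1cc(CCc2ccccc2)cc(OC)c1O` gives 1040 nM and compound 2 `COc1cc(CCc2ccc(Br)cc2)cc(OC)c1O` gives 1490 nM as the only numbers so far. These two values lie within the scatter of each other, so compound 2 stands level with compound 1. Compound 3 `COc1cc(CCc2ccc(Cl)cc2)cc(OC)c1O` has not yet been measured. Its difference from compound 2 is chloro in place of bromo on an aromatic carbon and amounts to chloro in place of bromo on an aromatic carbon, para to a large group. Among the compounds with values here, one measured step bears on this change. It is a 1.4-fold higher number from compound 1 to compound 2 (0.16 log units; within the scatter) and it exchanges hydrogen for bromo on an aromatic carbon. Within the data shown here, no chloro compound has been measured, so the evidence is thin. Because a 1.4-fold higher number from compound 1 to compound 2 (0.16 log units; within the scatter) stays within the scatter, no step beyond the scatter is expected in this assay for this exchange. The expected step is a 1.2-fold lower number from compound 2 to compound 3 (0.08 log units; within the scatter) and it would remain within the scatter. For compound 3 the estimated value is 1250 nM with an expected range from 650 nM to 2400 nM in this measurement.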

Compound 3, half-maximal inhibitory concentration: > 25000 nM
Compound 3: no number, only a limit; the forecaster's own chance of this, stated with the estimate: 1%; at least 20-fold (1.30 log units) between middle value and limit.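

In this assay, the aromatic carbon para to a large group no longer looks indifferent to what it carries: bromo in place of hydrogen gave only a 1.4-fold higher number from compound 1 to compound 2 (0.16 log units; within the scatter), yet chloro in place of bromo gives an at least 16-fold higher number from compound 2 to compound 3 (1.22 log units; beyond the scatter), and chloro in place of hydrogen gives an at least 24-fold higher number from compound 1 to compound 3 (1.38 log units; beyond the scatter). Compound 3 carries a limit of the assay and not a number: the limit of > 25000 nM in this assay, at which 1 of the 3 values shown sits. Both new steps lie beyond the scatter, so a swap of one halogen for another at this single position separates compounds on the same core, which the earlier pair gave no sign of.

As far as these compounds go, how far compound 3 lies past its limit stays unknown, and one chloro compound cannot show whether this break belongs to chloro alone or to this position. From the compounds shown here alone, whether fluoro, methyl or methoxy on the same carbon would stand level with compound 1 or fall away like compound 3, and whether chloro elsewhere on the ring would do the same, remains open.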